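This account rests on a few compounds, and the source may have more. Where it says the series, first, only, none or still open, it means among the compounds named here.

Compounds measured in an ADME assay on Huh-7 cells (Homo sapiens) for cytotoxicity; on this read-out lower numbers stand for higher toxicity in this test and higher numbers for lower toxicity in this test:
- compound 1, `CCN(CC)CCCNCc1cn(-c2ccc(F)cc2F)nc1-c1ccccc1C`: > 20000 nM
- compound 2, `Cc1ccccc1-c1nn(-c2ccc(F)cc2F)cc1CNCCCN1CCN(C)CC1`: > 20000 nM

Compound 1 reaches only a limit of this assay, > 20000 nM. Compound 2 likewise reaches only a limit, > 20000 nM. Within the data shown here, the single measured step, a step that the two limits leave unreadable from compound 1 to compound 2, therefore cannot be read in size or direction, and both compounds sit together at the limit of > 20000 nM in this assay, at which 2 of the 2 values shown sit, where compound 2 stands at the upper edge of what this assay reports.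

Compound 3, `Cc1ccccc1-c1nn(-c2ccc(F)cc2F)cc1CNC1CCN(S(C)(=O)=O)CC1`, is not yet measured. It differs from compound 2 by 1-(methylsulfonyl)piperidin-4-yl in place of 3-(4-methylpiperazin-1-yl)propyl on an amine nitrogen. Among the measured compounds shown here, no measured step bears readably on this change: the only comparison, from compound 1 to compound 2, is masked by two limits, and no other pair touches the amine substituent. Since the data reach no number for either measured compound, there is no ground to expect a step beyond the scatter in this assay. Compound 3 is therefore expected to give 20000 nM, within 12000 nM to 40000 nM, most probably again as a limit of this assay. The step from compound 2 to compound 3 is estimated as a number no higher from compound 2 to compound 3 (the limit leaves the size open).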

Compound 3, half-maximal cytotoxic concentration: > 20000 nM
Compound 3: only a limit was reported; the forecaster's own chance of this, stated with the estimate: 80%; the middle value sits exactly at the limit.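

In this assay compound 3 gives > 20000 nM as a limit and not a number, so the steps to it from compound 1 and compound 2 cannot be read: the limit of > 20000 nM in this assay, at which 3 of the 3 values shown sit. The compounds shown leave open whether any of the three amine substituents differs from the others in cytotoxicity on these cells.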